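Moving Away from the 3-Methoxyphenyl Group of Compound 3

The compounds below may be only part of what the source reports. "The series", "measured", "known", "first", "only" and "open" are said of these compounds alone.

In an in vitro ADME assay on microsomes from liver (Homo sapiens) for pharmacokinetics, read by LC-MS, with a stated time of 10 min, tested at 1 uM (a lower number here means slower removal, a higher number faster removal of the compound), compound 3 `COc1cccc(NC(=O)[C@H]2CN(C)C[C@@H]2c2ccc(/C=C/C(=O)Nc3ccccc3N)cc2)c1` gives 14 mL/min/kg, the highest of the three numbers. Compound 1 `CN1C[C@H](C(=O)Nc2ccc(C(F)(F)F)cc2)[C@@H](c2ccc(/C=C/C(=O)Nc3ccccc3N)cc2)C1` gives 6 mL/min/kg, and compound 2 `CN1C[C@H](C(=O)Nc2ccc(Br)cc2)[C@@H](c2ccc(/C=C/C(=O)Nc3ccccc3N)cc2)C1` gives 3 mL/min/kg. Compound 4 `CN1C[C@H](C(=O)Nc2ccc(F)c(Br)c2)[C@@H](c2ccc(/C=C/C(=O)Nc3ccccc3N)cc2)C1` carries 3-bromo-4-fluorophenyl in place of 3-methoxyphenyl on an amide-type nitrogen. Within the data shown here, two measured steps bear on this change, a 2.3-fold higher number from compound 1 to compound 3 (0.37 log units; beyond the scatter) and a 4.7-fold higher number from compound 2 to compound 3 (0.67 log units; beyond the scatter). Both are modest, and both introduce 3-methoxyphenyl and raise the number. Compound 4 gives up that group for a bromine-bearing ring, as found in compound 2, so a modest fall is expected, with the estimated change being a 2.8-fold lower number from compound 3 to compound 4 (0.45 log units; beyond the scatter). For compound 4, the estimated value is 5 mL/min/kg, with an expected range of 2.5 mL/min/kg to 11 mL/min/kg.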

Compound 4, clearance: 15 mL/min/kg
Compound 4: the middle estimate sits 3.0-fold (0.48 log units) below what was measured; measured number outside the range, above it.
By their numbers in this assay, from the lowest: compounds 2 and 1 (each within the scatter of the next); then compounds 3 and 4 (each within the scatter of the next).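

Bromine on the ring does not by itself hold the number down: with a 1.1-fold higher number from compound 3 to compound 4 (0.03 log units; within the scatter) as the step, 3-bromo-4-fluorophenyl stands level with 3-methoxyphenyl on this amide-type nitrogen. The new ring also sits apart from the other two, with a 5.0-fold higher number from compound 2 to compound 4 (0.70 log units; beyond the scatter) and a 2.5-fold higher number from compound 1 to compound 4 (0.40 log units; beyond the scatter) as its steps, so among these compounds bromine-bearing rings fall on both sides of compound 1. Nothing at hand accounts for this difference. The compounds shown leave open which of the two halogens goes with the higher number, and how an amine or a carboxylic acid on this ring would read.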